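A few compounds are considered here, and "the series" means these few. Any claim that something is new, unique, unknown or untested is made for them only; others in the source may bear on it.

Series notes, rat corticotropin-releasing factor receptor binding.

Measured compounds:
- compound 1 `CCC(CCOC)n1c(C2CC2)nc2c(-c3ccc(C(F)(F)F)cc3Cl)ccnc21` gives 20.8 nM in an assay for binding affinity to Corticotropin releasing factor receptor (Rattus norvegicus); a higher number here means a weaker inhibitor, a lower number a stronger inhibitor
- compound 2 `CCc1nc2c(-c3ccc(Cl)cc3Cl)ccnc2n1C(C)C1CCC1` gives 1 nM in this assay
- compound 3 `CCc1nc2c(-c3ccc(C(F)(F)F)cc3Cl)ccnc2n1C(CC)COC` gives 4.7 nM in this assay

Among these three numbers compound 2 stands lowest. Its nearest neighbour is compound 3, whose number is higher by a margin beyond the scatter, and the furthest is compound 1, whose number is higher still. Going by the values given here, none of the three pairs differs in one place only, so the three values are read side by side and no single step between them is counted.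

The compound to be tested next is compound 4 `CCc1nc2c(-c3ccc(Cl)cc3Cl)ccnc2n1C(C)CC`. It derives from compound 2 by one change: ethyl in place of cyclobutyl on a saturated chain carbon bound to an aromatic nitrogen and a saturated chain carbon. Among the compounds with values here, no measured pair in the set separates this change from others, so its size is not known from the data. The expectation is a move towards a higher number in this assay, that is, a loss of affinity, of a size that may be a little beyond the scatter rather than a large shift, since compound 2 gives 1 nM and a contraction from cyclobutyl to ethyl on the chain carbon bound to the aromatic nitrogen is the only difference. Compound 4 is thus estimated at 3 nM, with a range from 1 nM to 10 nM. The step this estimate implies is a 3.0-fold higher number from compound 2 to compound 4 (0.48 log units; beyond the scatter).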

Compound 4, inhibition constant: 1.3 nM
Compound 4: the middle estimate sits 2.3-fold (0.36 log units) above what was measured, and the stated range covers the measured number.
By their numbers in this assay, from the lowest: compounds 2 and 4 (each within the scatter of the next); then compound 3; then compound 1.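

In this assay the exchange of cyclobutyl for ethyl on a saturated chain carbon bound to an aromatic nitrogen and a saturated chain carbon comes to a 1.3-fold higher number from compound 2 to compound 4 (0.11 log units; within the scatter), so 1-cyclobutylethyl and sec-butyl are not told apart on this core. This pair gives the series its first reading of a single change, and it shows that here the four-membered ring of carbon only can give way to an open chain without a shift beyond the scatter, something the three earlier compounds, read only side by side, could not show. No measurement at hand accounts for the two groups reading alike.

As far as these compounds go, the result rests on one pair with one aryl group, so it remains open whether the same exchange would read alike on the trifluoromethyl-bearing aryl of compound 1 and compound 3, whose other differences mean that no further steps can be read. Also open, from the compounds shown here alone, is how the same chain carbon would respond to a cyclopentyl group, a longer alkyl chain, a hydroxyl or an amine.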